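The compounds below may be only part of what the source reports. "The series", "measured", "known", "first", "only" and "open" are said of these compounds alone.

Measured so far in an ADME assay on HCT-116 cells (Homo sapiens) for cytotoxicity, read by CellTiter-Glo, with a stated time of 72 h; a higher number here means a weaker inhibitor, a lower number a stronger inhibitor:
- compound 1 `CC1CCN(C2CCN(S(=O)(=O)c3ccc(C(C)C)cc3)CC2)CC1` gives > 5000 nM, a limit of the assay rather than a number.
- compound 2 `Cc1cc(C)c(S(=O)(=O)N2CCC(N3CCC(C)OC3)CC2)c(C)c1` gives > 5000 nM, again only a limit.
- compound 3 `CC1CCN(C2CCN(S(=O)(=O)c3cccnc3F)CC2)CC1` gives > 10000 nM, again only a limit.

Compound 1 therefore stands at the limit of > 5000 nM in this assay, at which 2 of the 3 values shown sit, where compound 2 also sits, while compound 3 sits at the limit of > 10000 nM in this assay, at which 1 of the 3 values shown sits. Among the measured compounds shown here, no step between measured compounds can be stated, since none of the three values is a number; all three compounds keep the shared core and differ only in the part outside it, and none of them reaches a measurable inhibition in this assay.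

Compound 4 `CC1CCN(C2CCN(S(=O)(=O)c3ccc(-c4ccc(Cl)cc4)cc3)CC2)CC1` is the next compound to be measured. It differs from compound 1 by 4-chlorophenyl in place of isopropyl on an aromatic carbon. For the measured compounds named here, no measured step of this kind exists, so the size and direction of the change cannot be read from the data. The expectation rests on compound 1 alone, which gives only > 5000 nM; the estimated step that the limit leaves unreadable from compound 1 to compound 4 is taken to be modest, with a real chance that compound 4 again returns only a limit. Compound 4 is thus expected to give about 6000 nM, within a range from 1500 nM to 30000 nM.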

Compound 4, half-maximal inhibitory concentration: > 5000 nM
Compound 4 was reported as a limit; the forecaster's own chance of this, stated with the estimate: 55%; the middle value does not contradict the limit.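

Compound 1 and compound 4 both return only a limit in this assay, so no step can be read for 4-chlorophenyl in place of isopropyl on an aromatic carbon: the limit of > 5000 nM in this assay, at which 3 of the 4 values shown sit.

The compounds shown leave open whether any change to the part outside the shared core gives a measurable value in this assay.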